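Trimming a Sulfonamide Side Chain Among Inactive Hydroxamates

The compounds below may be only part of what the source reports. "The series", "measured", "known", "first", "only" and "open" are said of these compounds alone.

Three hydroxamic acids have been tested in an assay on Sf9 cells for inhibition of histone deacetylase 8 (Homo sapiens), read by fluorescence and mobility shift assay; a higher number here means a weaker inhibitor, a lower number a stronger inhibitor. Compound 1 `CC(C)N(Cc1ccc(C(=O)NO)cc1)Cc1cc(F)c(F)c(F)c1F` is reported only as a limit, > 1000 nM. Compound 3 `CC(C)N(Cc1ccc(C(=O)NO)cn1)S(=O)(=O)c1cc(F)c(F)c(F)c1F` likewise gives a limit, > 1000 nM. Compound 2 `CC(C)CN(Cc1ccc(C(=O)NO)cc1)S(=O)(=O)c1cc(F)c(F)c(F)c1F`, the starting point here, is also reported as a limit, > 1000 nM. Because all three values rest at the limit of > 1000 nM in this assay, at which 3 of the 3 values shown sit, no ordering among them can be read. Compound 4 `CC(C)N(Cc1ccc(C(=O)NO)cc1)S(=O)(=O)c1cc(F)c(F)c(F)c1F`, not yet measured, carries isopropyl in place of isobutyl on a sulfonamide nitrogen. No measured step of this kind exists among these compounds, so the change is expected to be small and without a clear direction, staying within the usual scatter. For compound 4 in this assay the expected value is 3000 nM, with a range from 800 nM to 20000 nM. The step that the limit leaves unreadable from compound 2 to compound 4 is expected to be slight, and most likely only a limit will again be reported.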

Compound 4, half-maximal inhibitory concentration: > 1000 nM
Compound 4: a limit, no number; the forecaster's own chance of this, stated with the estimate: 80%; the middle value does not contradict the limit.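

No step can be read between compound 2 and compound 4, because both values are limits and not numbers: the limit of > 1000 nM in this assay, at which 4 of the 4 values shown sit.

The compounds shown leave open how strongly any of them acts in this assay, and whether isopropyl and isobutyl differ at all.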